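The source may report more compounds than this note shows. Statements on the series, on what has been measured and on what is new or still open speak of the compounds shown alone.

Three compounds share one core and differ only in the group on the aromatic nitrogen of the fused ring system. Compound 1 `Nc1ccccc1NC(=O)c1ccc(CNc2nc(Cl)nc3c2ncn3Cc2ccccc2)cc1` gives 46.4% in a functional assay on NCI-H460 cells (Homo sapiens) for antiproliferative activity, read by CCK-8 assay, with a stated time of 72 h, tested at 8 uM; a lower number here means a weaker effect, a higher number a stronger effect of the compound at the concentration tested; compound 2 `CCC(C)n1cnc2c(NCc3ccc(C(=O)Nc4ccccc4N)cc3)nc(Cl)nc21` gives 67.7%; compound 3 `CCCn1cnc2c(NCc3ccc(C(=O)Nc4ccccc4N)cc3)nc(Cl)nc21` gives 39.2%, the lowest of the three, with compound 1 within the scatter of it and compound 2 well clear of it. Compound 4 `Nc1ccccc1NC(=O)c1ccc(CNc2nc(Cl)nc3c2ncn3C2CCCC2)cc1` carries cyclopentyl in place of propyl on an aromatic nitrogen. The steps that touch this position are a number 21.3 percentage points higher from compound 1 to compound 2 (beyond the scatter) and a number 28.5 percentage points lower from compound 2 to compound 3 (beyond the scatter), while a number 7.2 percentage points lower from compound 1 to compound 3 (within the scatter). Of the three, sec-butyl in compound 2 stands highest, so a modest rise is expected for compound 4, namely a number 18.8 percentage points higher from compound 3 to compound 4 (beyond the scatter). Compound 4 is therefore estimated at 58%, between 42% and 74%.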

Compound 4, a percentage reported as inhibition, at one concentration (the size of the read-out at that concentration, not a potency): 57.4%
For compound 4 the middle estimate is 0.6 percentage points above the measured one, and the stated range covers the measured number.
By their numbers in this assay, from the lowest: compounds 3 and 1 (each within the scatter of the next); then compound 4; then compound 2.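

Cyclopentyl on this aromatic nitrogen shows that a saturated ring is accepted here, with a number 18.2 percentage points higher from compound 3 to compound 4 (beyond the scatter) and a number 11 percentage points higher from compound 1 to compound 4 (beyond the scatter), although it does not match sec-butyl, with a number 10.3 percentage points lower from compound 2 to compound 4 (beyond the scatter). Among the four compounds, the two groups branched at the carbon bound to the aromatic nitrogen, sec-butyl and cyclopentyl, now give the two highest numbers, and no compound shown goes against this. Nothing available explains these differences. The compounds shown leave open whether cyclopropyl or cyclohexyl would follow cyclopentyl. They also leave open how a chain ending in an amine would read.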